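Compound 2 and one added methyl

A few compounds are considered here, and "the series" means these few. Any claim that something is new, unique, unknown or untested is made for them only; others in the source may bear on it.

Measured in a functional assay on MCF7 cells (Homo sapiens) for cytotoxicity, read by MTT assay, with a stated time of 72 h (a lower number here means a stronger inhibitor, a higher number a weaker inhibitor), so far:
- compound 1 `CC(=O)O[C@H](C/C(C)=C/CO)[C@@]1(C)[C@H](C)CC=C2[C@@H]1CCCC2(C)C` gives > 30000 nM as a limit
- compound 2 `CCC(=O)OC/C=C(\C)C[C@@H](O)[C@@]1(C)[C@H](C)CC=C2[C@@H]1CCCC2(C)C` gives > 30000 nM as a limit

Going by the values given here, compound 2 has no exact number and sits at the limit of > 30000 nM in this assay, at which 2 of the 2 values shown sit, as its only reading. Compound 3 `CCCC(=O)OC/C=C(\C)C[C@@H](O)[C@@]1(C)[C@H](C)CC=C2[C@@H]1CCCC2(C)C` has not yet been measured. Its structure differs from that of compound 2 by methyl in place of hydrogen on a saturated chain carbon, two bonds along the chain from a carbonyl carbon, so that propanoyl becomes propylcarbonyl. Among the compounds with values here, no measured step between compounds is available to give the size of such a change. For this single methyl in place of hydrogen, no shift beyond the scatter in this assay is expected in either direction. The expected change, a number no higher from compound 2 to compound 3 (the limit leaves the size open), is an estimate and remains small. Compound 3 is estimated at 30000 nM, with an expected range from 15000 nM to 45000 nM, and may also return only a limit.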

Compound 3, half-maximal inhibitory concentration: > 30000 nM
Compound 3 ended at the assay's limit (the forecaster's own chance of this, stated with the estimate: 70%); the middle value sits exactly at the limit.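

Going by these compounds alone, compound 2 and compound 3 both end at a limit, so no step between them can be read. The compounds shown leave open what exact value any of them would give in this assay, and whether methyl in place of hydrogen at this place changes it at all.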